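The source may report more compounds than this note shows. Statements on the series, on what has been measured and on what is new or still open speak of the compounds shown alone.

Within the data shown here, in a functional assay on DU-145 cells (Homo sapiens) for cytotoxicity (on this read-out lower numbers stand for stronger inhibition of growth and higher numbers for weaker inhibition of growth), compound 2 (`COc1ccc(C2=C(c3ccc(SC)cc3)CC3CCCN3C2=O)cc1Br`) gives 900 nM as the lower of the two numbers so far, and compound 1 (`COc1ccc(C2=C(c3ccc(SC)cc3)CC3CCCN3C2=O)cc1OC(=O)C1CCCN1C(=O)OC(C)(C)C`) gives 5000 nM as the higher, a gap beyond the usual scatter. Compound 3 (`CSc1ccc(C2=C(c3ccc(O)cc3)C(=O)N3CCCC3C2)cc1`) carries 4-hydroxyphenyl in place of 3-bromo-4-methoxyphenyl on a double-bonded ring carbon. Among the measured compounds shown here, no measured step covers this change. In this assay a move toward weaker inhibition of growth is expected, with a 3.3-fold higher number from compound 2 to compound 3 (0.52 log units; beyond the scatter) as the estimated step beyond the scatter. In this assay the estimate for compound 3 is 3000 nM with an expected range of 1000 nM to 9000 nM for repeat measurements.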

Compound 3, concentration for 50% growth inhibition: > 100000 nM
Compound 3: only a limit was reported; the forecaster's own chance of this, stated with the estimate: 15%; middle value at least 33-fold (1.52 log units) away from the limit.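

In this assay, the substituent on the double-bonded ring carbon is shown to matter strongly: 4-hydroxyphenyl in place of 3-bromo-4-methoxyphenyl gives an at least 110-fold higher number from compound 2 to compound 3 (2.04 log units; beyond the scatter). Compound 1 and compound 2 both keep the methoxy group on this phenyl ring and both give measured numbers, whereas compound 3, which lacks it, does not. The value of compound 3 is a limit and not a number, so the full size of the step stays open: the limit of > 100000 nM in this assay, at which 1 of the 3 values shown sits.

This change removes the bromine and replaces methoxy with hydroxyl in one step, and the compounds shown do not separate the two. Going by these compounds, whether an amine in place of the hydroxyl would restore growth inhibition remains open.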